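The source may hold more compounds than are shown below. What is called first, only, known or untested is meant among the compounds shown, and "the series" means these compounds.

Measured so far:
compound 1 `CC(C)(C)c1cc(/C=C/C(=O)NC2CCN(Cc3ccccc3)CC2)cc(C(C)(C)C)c1O`, in a functional assay, read by spectrophotometry, with a stated time of 30 min (a higher number here means a weaker inhibitor, a lower number a stronger inhibitor), compound 1 gives 71900 nM
compound 2 `CC(C)(C)c1cc(/C=C/C(=O)NCCC2CCN(Cc3ccccc3)CC2)cc(C(C)(C)C)c1O`, compound 2 gives 81700 nM
compound 3 `CC(C)(C)c1cc(/C=C/C(=O)NCCC2CCN(Cc3ccc(F)cc3F)CC2)cc(C(C)(C)C)c1O`, compound 3 gives 62400 nM

The three numbers sit close together. Compound 2 stands at the high end, yet its gap to compound 1 is within the scatter, and a 1.3-fold lower number from compound 2 to compound 3 (0.12 log units; within the scatter) is within the scatter as well.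

Compound 4 `CC(C)(C)c1cc(/C=C/C(=O)NCCC2CCN(Cc3ccc(F)c(F)c3)CC2)cc(C(C)(C)C)c1O` differs from compound 2 by 3,4-difluorophenyl in place of phenyl on a saturated chain carbon bound to an amine nitrogen in a ring. For the measured compounds named here, the only step that bears on this is a 1.3-fold lower number from compound 2 to compound 3 (0.12 log units; within the scatter), which places two fluorines on the same ring in a different arrangement and produced no shift beyond the scatter. Going by the values given here, no step in this assay beyond the scatter is therefore expected for compound 4, so a 1.2-fold lower number from compound 2 to compound 4 (0.07 log units; within the scatter) is the expected change. Compound 4 is estimated at 70000 nM, with a range from 35000 nM to 140000 nM.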

Compound 4, half-maximal inhibitory concentration: 65700 nM
Estimate against measurement, compound 4: 1.1-fold (0.03 log units) above; the range from low to high includes it.
By their numbers in this assay, from the lowest: compounds 3, 4, 1 and 2 (each within the scatter of the next).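

In this assay, 3,4-difluorophenyl in place of phenyl on a saturated chain carbon bound to an amine nitrogen in a ring gives a 1.2-fold lower number from compound 2 to compound 4 (0.09 log units; within the scatter), so a second fluorine pattern on this ring also leaves the number within the scatter. The two patterns cannot be told apart, with a 1.1-fold higher number from compound 3 to compound 4 (0.02 log units; within the scatter) in this series. No accompanying measurement bears on this result.

Still open, going by these compounds, is whether a methoxy, a nitrile or a carboxylic acid on this ring gives a step beyond the scatter. On these data alone, a pyridine in place of the phenyl is equally open.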